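A few compounds are considered here, and "the series" means these few. Any claim that something is new, unique, unknown or untested is made for them only; others in the source may bear on it.

Measured so far:
Compound 1 `C=CCCCCCCCS(=O)(=O)/C=C/c1ccc(O)c(O)c1`: 6900 nM
Compound 2 `C=CCCCCCCS(=O)(=O)/C=C/c1ccc(O)c(O)c1`: 6400 nM
Compound 3 `O=S(=O)(/C=C/c1ccc(O)c(O)c1)CC1CCCCC1`: 7500 nM

In a functional assay, read by fluorescence and spectrophotometry, with a stated time of 1 h (on this read-out higher numbers stand for an effect only at larger amounts of compound and lower numbers for an effect already at smaller amounts), compound 3 gives 7500 nM, within the scatter of compound 1 and compound 2. Compound 4 `O=S(=O)(/C=C/c1ccc(O)c(O)c1)CCCCCCCO` has 6-hydroxyhexyl in place of cyclohexyl on a saturated chain carbon bound to a sulfonyl sulfur. Among the compounds with values here, two measured steps bear on this change. One is a 1.2-fold higher number from compound 2 to compound 3 (0.07 log units; within the scatter), with cyclohexyl in place of hept-6-en-1-yl at that same carbon. The other is a 1.1-fold lower number from compound 1 to compound 2 (0.03 log units; within the scatter), with vinyl in place of allyl further along the chain. Both lie within the scatter, yet neither brings in a hydroxyl group, so this evidence is indirect. The expected step is therefore small and without a firm direction in this assay: a 1.1-fold higher number from compound 3 to compound 4 (0.03 log units; within the scatter). For compound 4 the estimated value is 8000 nM, with an expected range of 3500 nM to 18000 nM.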

Compound 4, half-maximal effective concentration: 5900 nM
Compound 4: middle estimate off by 1.4-fold (0.13 log units), on the high side, within the range that was stated.
By their numbers in this assay, from the lowest: compounds 4, 2, 1 and 3 (each within the scatter of the next).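

In this assay, replacing the cyclohexyl ring with the open 6-hydroxyhexyl chain keeps the number within the scatter (a 1.3-fold lower number from compound 3 to compound 4 (0.10 log units; within the scatter)). Compound 4 also stays within the scatter of the two compounds with chains ending in a vinyl group (a 1.1-fold lower number from compound 2 to compound 4 (0.04 log units; within the scatter); a 1.2-fold lower number from compound 1 to compound 4 (0.07 log units; within the scatter)), so a hydroxy group, with its hydrogen-bond donor and acceptor, is tolerated at this position in these compounds. No supporting measurement explains this result. From the compounds shown here alone, whether an amine or a carboxylic acid in place of the hydroxy group, or a much shorter chain, would move the number beyond the scatter remains open.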